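Nitro to Cyano: Expecting Little Change in Growth Inhibition

This account rests on a few compounds, and the source may have more. Where it says the series, first, only, none or still open, it means among the compounds named here.

Of the compounds shown here, two built on a shared core have been measured in a functional assay on SN12C cells (Homo sapiens) for inhibition, read by sulforhodamine B assay, with a stated time of 48 h, tested at 10 uM; on this read-out lower numbers stand for less inhibition of growth and higher numbers for more inhibition of growth at the one concentration tested. Compound 1 `CC(=O)c1ccc(Nc2ccnc(SCC(=O)c3ccc(Br)cc3)n2)cc1` gives 14% in this assay. Compound 2 `CCOC(=O)c1ccc(Nc2ccnc(SCC(=O)c3ccc([N+](=O)[O-])cc3)n2)cc1` gives 17% in this assay, and the gap to compound 1 lies within the scatter of repeated measurements, so on the numbers shown compound 2 stands alongside compound 1 rather than apart from it, both showing only modest growth inhibition at the concentration tested.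

Compound 3 `CCOC(=O)c1ccc(Nc2ccnc(SCC(=O)c3ccc(C#N)cc3)n2)cc1` has not yet been measured. It differs from compound 2 in one place: cyano in place of nitro on an aromatic carbon. Among the measured compounds shown here, no step between measured compounds speaks to this change, so nothing in the data points to a direction. Since compound 2 sits at 17% and compound 1 sits at 14%, the step of a number 2 percentage points lower from compound 2 to compound 3 (within the scatter) is expected to stay within the scatter. Compound 3 is therefore estimated at 15%, with a range from 3% to 30%.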

Compound 3, percent growth inhibition at one concentration: 26%
Compound 3: the middle estimate sits 11 percentage points below what was measured, within the range that was stated.
By their numbers in this assay, from the lowest: compounds 1, 2 and 3 (each within the scatter of the next, the first and the last beyond it).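

In this assay the exchange of nitro for cyano on an aromatic carbon, para to a large group, gives a number 9 percentage points higher from compound 2 to compound 3 (within the scatter). Among the compounds shown here, this is the first step that changes only one place, and it shows that 4-nitrophenyl and 4-cyanophenyl are not told apart by this read-out, so the nitro group is not needed here to keep the modest growth inhibition seen with compound 2. No available evidence bears on this step.

For the compounds shown here, how an amine or a carboxylic acid would fare at this same place on the ring remains open, since both nitro and cyano leave only one kind of comparison to go on. Compound 1 differs from compound 2 in more than one place, so the part played by its bromo group on this ring also remains unresolved.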